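Working notes: trifluoromethyl in place of chloro

This account rests on a few compounds, and the source may have more. Where it says the series, first, only, none or still open, it means among the compounds named here.

The three measured compounds share one core and differ in a single group on an aromatic carbon. In a functional assay on HCT-116 cells (Homo sapiens) for antiproliferative activity, read by MTT assay, with a stated time of 24 h (a lower number here means a stronger inhibitor, a higher number a weaker inhibitor), compound 1 `COc1cc(OC)c(-c2coc3cc(OCc4ccc([N+](=O)[O-])cc4)ccc3c2=O)cc1OC` gives > 10000 nM, which is a limit of the assay and not a number. Compound 2 `COc1cc(OC)c(-c2coc3cc(OCc4ccc(C#N)cc4)ccc3c2=O)cc1OC` gives 4220 nM. Compound 3 `COc1cc(OC)c(-c2coc3cc(OCc4ccc(Cl)cc4)ccc3c2=O)cc1OC` gives 4450 nM. The last two values lie within the scatter of each other, with a 1.1-fold higher number from compound 2 to compound 3 (0.02 log units; within the scatter), so compound 3 stands level with compound 2.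

Leaving nitro gives an at least 2.3-fold lower number from compound 1 to compound 2 (0.37 log units; beyond the scatter) and an at least 2.2-fold lower number from compound 1 to compound 3 (0.35 log units; beyond the scatter). Both steps are beyond the scatter, and both are bounds rather than exact sizes.

Compound 4 `COc1cc(OC)c(-c2coc3cc(OCc4ccc(C(F)(F)F)cc4)ccc3c2=O)cc1OC` carries trifluoromethyl in place of chloro on an aromatic carbon, para to a large group: trifluoromethyl in place of chloro on an aromatic carbon. Among the measured compounds shown here, no measured step involves trifluoromethyl. The closest guide is the exchange of chloro and cyano, a 1.1-fold higher number from compound 2 to compound 3 (0.02 log units; within the scatter), which stays within the scatter. Only compound 1 has departed from the other values, so no step beyond the scatter is expected in this assay. The expected change is a 1.0-fold higher number from compound 3 to compound 4 (0.00 log units; within the scatter), which is within the scatter. The estimated value for compound 4 is 4500 nM, with an expected range from 2200 nM to 9500 nM.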

Compound 4, half-maximal inhibitory concentration: 2440 nM
Beside the measured number, compound 4's estimate is 1.8-fold (0.27 log units) above it; the range from low to high includes it.
By their numbers in this assay, from the lowest: compounds 4, 2 and 3 (each within the scatter of the next). At a limit, above all of these: compound 1.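

In this assay, trifluoromethyl on this aromatic carbon, para to a large group, brings more heavy atoms than chloro yet leaves the series level, with a 1.8-fold lower number from compound 3 to compound 4 (0.26 log units; within the scatter) and a 1.7-fold lower number from compound 2 to compound 4 (0.24 log units; within the scatter) both printed as within the scatter. Compounds 2, 3 and 4 therefore form a group of three that cannot be separated in this assay, so this position tolerates the change from chloro to trifluoromethyl without a readable shift, and compound 1, with nitro, is the only compound shown that goes against this level. Among the compounds shown here, the new comparison with nitro gives an at least 4.0-fold lower number from compound 1 to compound 4 (0.61 log units; beyond the scatter) as the largest step so far, but it remains a bound and not an exact size: the limit of > 10000 nM in this assay, at which 1 of the 4 values shown sits.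

Going by these compounds, it remains open how far compound 1 truly lies from the other three, and whether nitro is a lone exception at this position. Also open, on these data alone, is whether a group of another kind here, such as an amine, a carboxylic acid or a longer chain, would leave the level held by compounds 2, 3 and 4.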